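This account rests on a few compounds, and the source may have more. Where it says the series, first, only, none or still open, it means among the compounds named here.

Of the compounds shown here, two have so far been measured in a functional assay on cells for antagonist activity at Glucagon receptor (Homo sapiens), read by cAMP accumulation, in the presence of a further agent that is not named here; on this read-out higher numbers stand for weaker inhibition and lower numbers for stronger inhibition. Compound 1 `CCCC(Nc1ccc(-n2cc(C(F)(F)F)cn2)nc1)c1ccc(C(=O)NCCC(=O)O)cc1` gives 1300 nM in this assay, and compound 2 `CCCC(Oc1ccc(-n2cc3ccccc3n2)cc1)c1ccc(C(=O)NCCC(=O)O)cc1` gives 2000 nM. Compound 2 thus has the higher of the two numbers, but its gap to compound 1 lies within the scatter, so the two cannot be told apart on these data. Compound 3 `CCCC(Oc1ccc(-n2cc(F)cn2)cc1)c1ccc(C(=O)NCCC(=O)O)cc1` has not yet been measured. It differs from compound 2 in one place: 4-fluoro-1H-pyrazol-1-yl in place of 2H-indazol-2-yl on an aromatic carbon. For the measured compounds named here, no measured pair shows this change on its own, so its size cannot be read from the data. Compound 1 carries a related five-membered group bearing trifluoromethyl instead of fluorine, together with a different linker and a different six-membered ring, and its value of 1300 nM sits close to that of compound 2, which shows that a pyrazole-type group of this kind is compatible with a number in the same range. Compound 3 is therefore expected to show a step of a 1.3-fold lower number from compound 2 to compound 3 (0.12 log units; within the scatter), not beyond the scatter. Compound 3 is estimated at 1500 nM, with a range from 500 nM to 5000 nM.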

Compound 3, antagonist equilibrium constant: 10000 nM
For compound 3 the middle estimate is 6.7-fold (0.82 log units) below the measured one, outside the stated range (above it).
By their numbers in this assay, from the lowest: compounds 1 and 2 (each within the scatter of the next); then compound 3.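

In this assay, for the compounds shown here, 4-fluoro-1H-pyrazol-1-yl in place of 2H-indazol-2-yl gives a 5.0-fold higher number from compound 2 to compound 3 (0.70 log units; beyond the scatter) and is the first single change in this set that can be read on its own. It shows that the group on this aromatic carbon, para to a large group, is not freely interchangeable: inhibition weakens beyond the scatter when the six-membered aromatic ring of carbon only leaves and a fluorine enters, even though the counted hydrogen-bond donors, hydrogen-bond acceptors and net charge stay the same. No measurement among these compounds accounts for this loss of inhibition.

From the compounds shown here alone, the step joins two changes, the loss of the six-membered ring and the gain of fluorine, so their separate shares remain unknown; a plain 1H-pyrazol-1-yl group, with hydrogen in place of the fluorine, would separate them at this position. Going by these compounds, whether the same replacement would have a similar effect on the core of compound 1 also remains open.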